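Ethyl for piperidin-3-yl in a growth inhibition series

The source may hold more compounds than are shown below. What is called first, only, known or untested is meant among the compounds shown, and "the series" means these compounds.

- Compound 1 `CN(C)c1cc(-c2cc(N3C[C@H](O)[C@@H](O)C3)ccc2O)nc(N)n1` in a functional assay on EJ cells (Homo sapiens) for cytotoxicity, with a stated time of 48 h (on this read-out higher numbers stand for weaker inhibition of growth and lower numbers for stronger inhibition of growth), gives "not determined" (no result reported) as its entry
- Compound 2 `Nc1nc(-c2cc(N3C[C@H](O)[C@@H](O)C3)ccc2O)cc(C2CCNCC2)n1` in this assay gives "not determined" (no result reported) as its entry
- Compound 3 `Nc1nc(-c2cc(N3C[C@H](O)[C@@H](O)C3)ccc2O)cc(C2CCCNC2)n1` in this assay gives > 10000 nM as its entry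

Compound 1 and compound 2 offer no result to compare, so the account turns to compound 3. In this assay compound 3 reads > 10000 nM and this is a limit of the assay, not a number. The measured picture therefore rests on the limit of > 10000 nM in this assay, at which 1 of the 3 values shown sits, and on no single value.

The next compound is compound 4 `CCc1cc(-c2cc(N3C[C@H](O)[C@@H](O)C3)ccc2O)nc(N)n1`, which has ethyl in place of piperidin-3-yl on an aromatic carbon of the six-membered aromatic ring with 2 nitrogen. The rest of the shared core stays as it is (ethyl in place of piperidin-3-yl on an aromatic carbon).

Within the data shown here, no pair of measured compounds differs in one place, so the data offer no direct guide to the size of this change in this assay and any expectation stays cautious. No step beyond the scatter is firmly expected, with at most a small move toward stronger inhibition of growth. The estimated step of an at least 1.1-fold lower number from compound 3 to compound 4 (0.04 log units; that floor lies within the scatter) is accordingly small and uncertain. For compound 4 the estimated value is 9000 nM with an expected range from 2000 nM to 40000 nM in this series.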

Compound 4, concentration for 50% growth inhibition: 1500 nM
The estimate for compound 4 lay 6.0-fold (0.78 log units) above the measured number; measured number outside the range, below it.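

Compound 4 gives the series its first single number, and it shows that the aromatic carbon of the six-membered aromatic ring with 2 nitrogen does not need piperidin-3-yl for growth inhibition to be read as a number in this assay. Replacing that substituent with ethyl, which has no ring and 0 hydrogen-bond donors, gives an at least 6.6-fold lower number from compound 3 to compound 4 (0.82 log units; beyond the scatter), so this change moves the read-out beyond the scatter, and the true step may be larger than the printed floor. Compound 3 stands at > 10000 nM, a limit of the assay and not a number, and the size of the step rests on that limit: the limit of > 10000 nM in this assay, at which 1 of the 4 values shown sits.

Ethyl differs from piperidin-3-yl in ring, size and ring nitrogen all at once, so the compounds shown do not say which of these differences matters; a cyclohexyl group, which keeps a six-membered ring without the nitrogen, would begin to separate them. Going by these compounds, how a smaller methyl group or a longer chain such as butyl on the same carbon would compare with compound 4 also remains open.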